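Swapping a Bromo Group for Methoxy on the Aryl Ring

The source may report more compounds than this note shows. Statements on the series, on what has been measured and on what is new or still open speak of the compounds shown alone.

Of the compounds shown here, three sharing one core have been measured in a functional assay on MCF7 cells (Homo sapiens) for inhibition, read by MTT assay, with a stated time of 72 h; a lower number here means a stronger inhibitor, a higher number a weaker inhibitor. Compound 1, `O=C(Nc1ccc(Oc2ccnc3[nH]ccc23)cc1)c1cn(-c2ccccc2)c2ccccc2c1=O`, carries no substituent on its terminal phenyl ring and gives 3560 nM. Compound 2, `O=C(Nc1ccc(Oc2ccnc3[nH]ccc23)cc1)c1cn(-c2ccc(Cl)cc2)c2ccccc2c1=O`, bears a chloro group there and gives 1590 nM. Compound 3, `O=C(Nc1ccc(Oc2ccnc3[nH]ccc23)cc1)c1cn(-c2ccc(Br)cc2)c2ccccc2c1=O`, bears a bromo group and gives 610 nM, the lowest number of the three, separated from compound 2 by more than the usual scatter and from compound 1 by a wider margin still. Across the set the steps run a 2.2-fold lower number from compound 1 to compound 2 (0.35 log units; beyond the scatter), a 5.8-fold lower number from compound 1 to compound 3 (0.77 log units; beyond the scatter) and a 2.6-fold lower number from compound 2 to compound 3 (0.42 log units; beyond the scatter).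

Compound 4, `COc1ccc(-n2cc(C(=O)Nc3ccc(Oc4ccnc5[nH]ccc45)cc3)c(=O)c3ccccc32)cc1`, is the next variation: methoxy in place of bromo on an aromatic carbon. For the measured compounds named here, none of the measured steps involves a methoxy group, so no step bears directly on this change. What the measured steps do show is that compound 1, with hydrogen at this position, gave the highest number and that chloro sat between hydrogen and bromo. A methoxy group is neither of these, so the direction of the change is uncertain, and the step from compound 3 to compound 4 in this assay is expected to be a 2.8-fold higher number from compound 3 to compound 4 (0.45 log units; beyond the scatter), most likely upward. Compound 4 is therefore estimated at 1700 nM, within a range from 450 nM to 6500 nM.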

Compound 4, half-maximal inhibitory concentration: 4650 nM
Compound 4: the middle estimate sits 2.7-fold (0.44 log units) below what was measured; the range from low to high includes it.
By their numbers in this assay, from the lowest: compound 3; then compound 2; then compounds 1 and 4 (each within the scatter of the next).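

In this assay, methoxy does not keep what bromo achieved at this position: the change gives a 7.6-fold higher number from compound 3 to compound 4 (0.88 log units; beyond the scatter), and against chloro it gives a 2.9-fold higher number from compound 2 to compound 4 (0.47 log units; beyond the scatter). Against plain hydrogen the change gives a 1.3-fold higher number from compound 1 to compound 4 (0.12 log units; within the scatter), so compound 1 and compound 4 cannot be told apart here, and among these four compounds only the two halogen-bearing ones, compound 2 and compound 3, stand out with lower numbers. Nothing available explains why bromo and methoxy differ so widely at this spot.

The compounds shown cannot say whether the preference for halogens extends to iodo, or whether a small carbon group such as methyl, an amine or a carboxylic acid at the same position would behave like bromo or like methoxy. They also leave open whether bromo would give a similar result at another place on the same ring, and whether the order of these four compounds would hold in a different cell line.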